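This account rests on a few compounds, and the source may have more. Where it says the series, first, only, none or still open, it means among the compounds named here.

Compound 3 `Fc1ccccc1Cn1nnc2c(NC3CCCCC3)nc(-c3ccccc3)nc21` gives the lowest of the three numbers recorded in an assay on isolated protein for binding affinity to adenosine receptor A1 (Bos taurus); a lower number here means a stronger inhibitor, a higher number a weaker inhibitor: compound 3 gives 1150000 nM. Its nearest neighbour is compound 1 `CCCNc1nc(-c2ccccc2)nc2c1nnn2Cc1ccccc1`, which in this assay gives 37000000 nM, and the furthest is compound 2 `OCCNc1nc(-c2ccccc2)nc2c1nnn2Cc1ccccc1F`, which in this assay gives 54000000 nM. Compound 4 `CCCNc1nc(-c2ccccc2)nc2c1nnn2Cc1ccccc1F` has not yet been measured in this assay. It differs from compound 3 in one place: propyl in place of cyclohexyl on a nitrogen on an aromatic ring.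

Within the data shown here, one measured step bears on this change: the step of a 47-fold lower number from compound 2 to compound 3 (1.67 log units; beyond the scatter), in which cyclohexyl replaced 2-hydroxyethyl on the same nitrogen and the number fell sharply. Compound 4 goes the other way, removing the cyclohexyl in favour of a short propyl chain, so a rise in the number is expected. Compound 1 also carries propyl on that nitrogen, though it differs from compound 3 in a second place as well, and its value in this assay is far higher than that of compound 3. Taken together, compound 4 is expected to show a step of a 26-fold higher number from compound 3 to compound 4 (1.42 log units; beyond the scatter) in this assay, that is, a clearly weaker binder than compound 3. Accordingly, compound 4 is estimated at 30000000 nM in this assay, with a likely range from 7000000 nM to 120000000 nM.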

Compound 4, inhibition constant: 3200000 nM
The estimate for compound 4 lay 9.4-fold (0.97 log units) above the measured number; measured number below the stated range.
By their numbers in this assay, from the lowest: compound 3; then compound 4; then compounds 1 and 2 (each within the scatter of the next).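

In this assay, among these compounds, the ring of the cyclohexyl group counts for less at this nitrogen than the earlier compounds suggested, as exchanging cyclohexylamino for propylamino gives only a modest step (a 2.8-fold higher number from compound 3 to compound 4 (0.44 log units; beyond the scatter)). Most of the large fall seen earlier (a 47-fold lower number from compound 2 to compound 3 (1.67 log units; beyond the scatter)) is kept with the open propyl chain, and replacing hydroxy with methyl on the saturated chain carbon already gives a large step (a 17-fold lower number from compound 2 to compound 4 (1.23 log units; beyond the scatter)), so at this nitrogen the loss of the hydroxy accounts for more of the fall than the arrival of a ring. The high number of compound 1 also proves not to be a reading of propyl alone, since fluoro in place of hydrogen on an aromatic carbon, with propyl kept, gives a large step of its own (a 12-fold lower number from compound 1 to compound 4 (1.06 log units; beyond the scatter)).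

Nothing at hand accounts for any of these steps. Still open, from the compounds shown here alone, is how this nitrogen would respond to a longer chain, to isopropyl or to a cyclopentyl ring, and whether the fluoro step would hold with cyclohexyl on the nitrogen.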